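This account rests on a few compounds, and the source may have more. Where it says the series, first, only, none or still open, it means among the compounds named here.

Compound 1, `ClCc1ccc(Cn2cnc3c(Cl)ncnc32)cc1`, is the stronger of the two measured compounds on the numbers in hand. In a functional assay on NCI-H460 cells (Homo sapiens) for cytotoxicity, read by sulforhodamine B assay, with a stated time of 48 h (on this read-out higher numbers stand for weaker inhibition of growth and lower numbers for stronger inhibition of growth), compound 1 gives 1820 nM. Within the data shown here, compound 2, `ClCc1ccccc1Cn1cnc2nc(Cl)nc(Cl)c21`, differs from it in more than one place, and in this assay compound 2 gives 5880 nM, a higher number that lies beyond the usual scatter; since the two structures differ in several places at once, the pair shows only that compound 2 is the weaker of the two, not which change accounts for it.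

Compound 3, `ClCc1ccc(Cn2cnc3c(Cl)nc(Cl)nc32)cc1`, has not yet been measured in this assay. It differs from compound 1 in one place: chloro in place of hydrogen on an aromatic carbon. Among the measured compounds shown here, no step between two measured compounds that differ only in this way is available, so the expectation rests on the single measured pair and on the change itself. The step from compound 1 to compound 3 is estimated to be small, a 1.4-fold higher number from compound 1 to compound 3 (0.14 log units; within the scatter), most likely a slight weakening, and possibly none beyond the scatter. Compound 3 is therefore expected to give about 2500 nM in this assay, within a range from 900 nM to 7000 nM.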

Compound 3, concentration for total growth inhibition: 4900 nM
The estimate for compound 3 lay 2.0-fold (0.29 log units) below the measured number; the range from low to high includes it.
By their numbers in this assay, from the lowest: compound 1; then compounds 3 and 2 (each within the scatter of the next).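

With the pair compound 1 and compound 3, the shared core gains its first single-place comparison, and it shows that this position is not silent in this assay. Chloro in place of hydrogen on the aromatic carbon between two ring nitrogen atoms gives (a 2.7-fold higher number from compound 1 to compound 3 (0.43 log units; beyond the scatter)), a modest step beyond the scatter in the direction of weaker inhibition of growth, so the hydrogen of compound 1 is the better of the two substituents tested here. Nothing at hand bears on the cause of this step.

From the compounds shown here alone, what an amine, a methoxy group or a fluoro at this position would do remains open, since one step cannot tell whether the rise belongs to chloro itself or would follow any replacement of hydrogen there. Going by these compounds, it is also open whether the step would keep its size with the chloromethyl group placed as it is in compound 2, as the one-place comparison available here has the chloromethyl group placed as in compound 1.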